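The compounds below may be only part of what the source reports. "The series", "measured", "known", "first", "only" and "open" are said of these compounds alone.

Compound 1 `CC(=O)Nc1ccc(/C=N/Nc2nc(N)c3ncn([C@@H]4O[C@H](CO)[C@@H](O)[C@H]4O)c3n2)cc1` is tested in an assay on CHO-K1 cells for displacement of a labelled ligand from adenosine receptor A1 (Homo sapiens), read by scintillation counting, with a stated time of 60 min; a higher number here means a weaker inhibitor, a lower number a stronger inhibitor. Compound 1 reaches only the limit of this assay, giving > 10000 nM, a boundary rather than a measured number. Two related compounds share the same core and differ only in the group on the carbon with a double bond to nitrogen. Compound 3 `Nc1nc(N/N=C/c2ccc(-c3ccccc3)cc2)nc2c1ncn2[C@@H]1O[C@H](CO)[C@@H](O)[C@H]1O` carries a phenyl in place of the acetamido on an aromatic carbon, and in this assay compound 3 gives 7860 nM. That change amounts to an at least 1.2-fold lower number from compound 1 to compound 3 (0.10 log units; that floor lies within the scatter). Compound 2 `Nc1nc(N/N=C/c2ccc(C(F)(F)F)cc2C(F)(F)F)nc2c1ncn2[C@@H]1O[C@H](CO)[C@@H](O)[C@H]1O` carries two trifluoromethyl groups on its outer ring, and compound 2 also sits at the limit with > 10000 nM. Compound 4 `Nc1nc(N/N=C/c2ccc(Cl)c(C(F)(F)F)c2)nc2c1ncn2[C@@H]1O[C@H](CO)[C@@H](O)[C@H]1O` has not yet been measured. Its change from compound 1 is 4-chloro-3-(trifluoromethyl)phenyl in place of 4-acetamidophenyl on a carbon with a double bond to nitrogen. Within the data shown here, the single measured step, the one to compound 3, barely moves the number, and the closest structural relative, compound 2, sits at the limit of > 10000 nM in this assay, at which 2 of the 3 values shown sit. Little movement is therefore expected, with a real chance of another limit. Compound 4 is estimated to give 15000 nM, with a range from 5000 nM to 50000 nM. The expected step is a step that the limit leaves unreadable from compound 1 to compound 4.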

Compound 4, inhibition constant: > 10000 nM
Compound 4 ended at the assay's limit (the forecaster's own chance of this, stated with the estimate: 70%); the middle value does not contradict the limit.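

Compound 1 and compound 4 both end at a limit in this assay, so the step between them cannot be read. Most values shown sit at that boundary: the limit of > 10000 nM in this assay, at which 3 of the 4 values shown sit. The compounds shown leave open how weak compound 1, compound 2 and compound 4 truly are.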